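Chloro to tert-butylamino on the compound 3 scaffold

This account rests on a few compounds, and the source may have more. Where it says the series, first, only, none or still open, it means among the compounds named here.

Measured in a functional assay on HepG2 cells (Homo sapiens) for cytotoxicity, read by MTT assay, with a stated time of 48 h; a higher number here means a weaker inhibitor, a lower number a stronger inhibitor:
- compound 1 `CC1=NN(C(=O)c2ccc([N+](=O)[O-])cc2)C(c2ccccc2O)C1`: 30100 nM
- compound 2 `CC1=NN(C(=O)COc2ccc(Cl)cc2)C(c2cc(Br)ccc2O)C1`: "not active" (no number reported)
- compound 3 `O=C(CCl)N1N=C(c2cc3ccccc3oc2=O)CC1c1ccccc1`: 2980 nM

Compound 3 holds the lower of the two numbers, at 2980 nM. Compound 1 at 30100 nM lies beyond the scatter from compound 3, and compound 2 offers no number for comparison.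

Compound 4 `CC(C)(C)NCC(=O)N1N=C(c2cc3ccccc3oc2=O)CC1c1ccccc1` keeps the core of compound 3 and carries (tert-butyl)amino in place of chloro on a saturated chain carbon bound to a carbonyl carbon. Among the compounds with values here, no measured pair shows this change, so its size in this assay can only be judged loosely. The estimate starts from compound 3 at 2980 nM, and a modest move toward a higher number is expected, possibly not clearing the scatter. The expected change is a 2.0-fold higher number from compound 3 to compound 4 (0.30 log units; within the scatter). The estimated value for compound 4 is 6000 nM, with an expected range from 1500 nM to 30000 nM.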

Compound 4, half-maximal inhibitory concentration: 31400 nM
Compound 4: the middle estimate sits 5.2-fold (0.72 log units) below what was measured; measured number outside the range, above it.
By their numbers in this assay, from the lowest: compound 3; then compounds 1 and 4 (each within the scatter of the next).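

In this assay, (tert-butyl)amino in place of chloro on a saturated chain carbon bound to a carbonyl carbon gives an 11-fold higher number from compound 3 to compound 4 (1.02 log units; beyond the scatter), the first single-place change readable in the series. With the core of compound 3 held fixed, this position is thus shown to be sensitive to its substituent: the exchange replaces 1 heavy atom with 5 and adds 1 hydrogen-bond donor and 1 hydrogen-bond acceptor, and the step lies beyond the scatter. Nothing at hand accounts for the size of this step.

From the compounds shown here alone, it remains open whether the step tracks the departure of chloro or the arrival of (tert-butyl)amino. A methylamino or morpholine group at this place would help separate those two readings, and would show whether other amines follow compound 4 or stay closer to compound 3.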